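Notes on swapping pentan-3-yl for sec-butyl

This account rests on a few compounds, and the source may have more. Where it says the series, first, only, none or still open, it means among the compounds named here.

compound 1 `CCC(CC)[C@@H]1C(=O)N[C@H](C2Cc3ccccc3C2)C(=O)N1[C@@H](C(=O)N1CCOCC1)c1ccc(C)nc1`: 55%
compound 2 `CCC(CC)[C@@H]1C(=O)N[C@H](C2Cc3ccccc3C2)C(=O)N1[C@@H](C(=O)N1CCOCC1)c1ccc(C)nc1C`: 42%

In an in vivo ADME assay on the whole organism for pharmacokinetics, with Rattus norvegicus as the target, at a dose of 5 mg/kg by the oral route (on this read-out lower numbers stand for lower oral bioavailability and higher numbers for higher oral bioavailability), compound 1 holds the higher of the two numbers. Compound 3 `CC[C@@H](C)[C@@H]1C(=O)N[C@H](C2Cc3ccccc3C2)C(=O)N1[C@@H](C(=O)N1CCOCC1)c1ccc(C)nc1` is not yet measured. It differs from compound 1 by sec-butyl in place of pentan-3-yl on a saturated ring carbon. For the measured compounds named here, the only measured step, a number 13 percentage points lower from compound 1 to compound 2 (beyond the scatter), is modest and concerns methyl in place of hydrogen on an aromatic carbon, so it bears only loosely on this change. No step beyond the scatter is expected in this assay, and the direction is open. The expected step is a number 5 percentage points lower from compound 1 to compound 3 (within the scatter). The estimate for compound 3 is 50%, with a range of 32% to 66%.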

Compound 3, oral bioavailability: 44%
Compound 3: the middle estimate sits 6 percentage points above what was measured; low and high end bracket the measured number.
By their numbers in this assay, from the lowest: compounds 2 and 3 (each within the scatter of the next); then compound 1.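

Replacing pentan-3-yl with sec-butyl on this saturated ring carbon is not a silent change in this assay: it gives a number 11 percentage points lower from compound 1 to compound 3 (beyond the scatter). For the compounds shown here, the earlier step concerned only an aromatic carbon, so this is the first sign that oral bioavailability also responds to the group at this position, with pentan-3-yl the higher of the two. No available measurement bears on what lies behind this step.

On these data alone, whether isopropyl, cyclopentyl or a longer chain here would match or exceed pentan-3-yl remains open. Also open, as far as these compounds go, is whether the same swap gives a similar step on the core of compound 2.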